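Cyclopropylcarbonyl to benzoyl on a bicyclic pyrazole series

This account rests on a few compounds, and the source may have more. Where it says the series, first, only, none or still open, it means among the compounds named here.

Measured compounds:
compound 1 `CCCCNC(=O)N1Cc2c(NC(=O)c3ccc(OC)cc3)nn(C(=O)C3CC3)c2C1` gives 65500 nM in a functional assay on HCT-116 cells (Homo sapiens) for cytotoxicity, read by sulforhodamine B assay, with a stated time of 48 h; on this read-out higher numbers stand for weaker inhibition and lower numbers for stronger inhibition
compound 2 `CCCCNC(=O)N1Cc2c(NC(=O)c3ccc(OC)cc3)nn(C(=O)c3ccccc3)c2C1` gives 25300 nM in this assay
compound 3 `O=C(Nc1nn(C(=O)C2CC2)c2c1CN(C(=O)c1ccccc1)C2)c1ccc(F)cc1` gives 2280 nM in this assay

Compound 3 has the lowest number of the three. The difference between the core of compound 1 and the core of compound 3 is not broken down here.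

Compound 4 `O=C(Nc1nn(C(=O)c2ccccc2)c2c1CN(C(=O)c1ccccc1)C2)c1ccc(F)cc1` is not yet measured. It differs from compound 3 by phenyl in place of cyclopropyl on a carbonyl carbon. The same change, (phenyl in place of cyclopropyl on a carbonyl carbon), was measured once: a 2.6-fold lower number from compound 1 to compound 2 (0.41 log units; beyond the scatter). The place line reads the same in both pairs, so this is the same change.

On that single precedent, a step of similar size is expected for compound 4: a 2.5-fold lower number from compound 3 to compound 4 (0.40 log units; beyond the scatter). Compound 4 is therefore estimated at 900 nM, with a range of 300 nM to 3000 nM, resting only on one prior step and on the value of compound 3.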

Compound 4, half-maximal inhibitory concentration: 2780 nM
Compound 4: the middle estimate sits 3.1-fold (0.49 log units) below what was measured; the range from low to high includes it.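

In this assay, the change gives a 1.2-fold higher number from compound 3 to compound 4 (0.09 log units; within the scatter), so the step seen on the core of compound 1 does not reappear on the core of compound 3. The two steps differ: the same change on two cores in this assay, a 2.6-fold lower number (0.41 log units; beyond the scatter) from compound 1 to compound 2 and a 1.2-fold higher number (0.09 log units; within the scatter) from compound 3 to compound 4, 3.2-fold (0.50 log units) apart, beyond the scatter of two such steps. This shows that, on these two pairs, the step cannot be carried unchanged from one core to the other; it does not show which of the several differences between compound 1 and compound 3 matters.

Open, from the compounds shown here alone, is how a longer alkyl chain or an amine in place of cyclopropyl on that carbonyl carbon would behave on either core. Also open, going by these compounds, is whether a core differing from compound 3 in one place only would keep the larger or the smaller step.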